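The source may hold more compounds than are shown below. What is called first, only, known or untested is meant among the compounds shown, and "the series" means these compounds.

In a functional assay on BXPC-3 cells (Homo sapiens) for antiproliferative activity, read by MTT assay, with a stated time of 24 h (a higher number here means a weaker inhibitor, a lower number a stronger inhibitor), compound 1 `CCn1c(C(=O)N[C@H](C)C(=O)OC)ccc1C(CC)(CC)c1ccc(OCS(=O)(=O)c2ccccc2)c(C)c1` gives only a limit of the assay, > 50000 nM. Compound 2 `CCn1c(C(=O)NCCO)ccc1C(CC)(CC)c1ccc(OCS(=O)(=O)c2ccccc2)c(C)c1` gives 19900 nM, and compound 3 `CCn1c(C(=O)N[C@H](CO)CCO)ccc1C(CC)(CC)c1ccc(OCS(=O)(=O)c2ccccc2)c(C)c1` gives 15900 nM. The steps of an at least 2.5-fold lower number from compound 1 to compound 2 (0.40 log units; beyond the scatter) and an at least 3.1-fold lower number from compound 1 to compound 3 (0.49 log units; beyond the scatter) both lower the number beyond the scatter, while the step of a 1.3-fold lower number from compound 2 to compound 3 (0.10 log units; within the scatter) stays within it. Compound 4 `CCn1c(C(=O)N[C@H](CO)CCCO)ccc1C(CC)(CC)c1ccc(OCS(=O)(=O)c2ccccc2)c(C)c1` differs from compound 1 by a group of 7 heavy atoms (5 carbon, 2 oxygen; no ring) in place of a group of 6 heavy atoms (4 carbon, 2 oxygen; no ring), on an amide-type nitrogen. This change resembles those leading to compound 2 and compound 3, where hydrogen-bond donors replace the ester-bearing group, so in this assay compound 4 is expected to show a step of an at least 3.3-fold lower number from compound 1 to compound 4 (0.52 log units; beyond the scatter). The estimated value for compound 4 is 15000 nM, with a likely range from 6000 nM to 40000 nM.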

Compound 4, half-maximal inhibitory concentration: > 50000 nM
Compound 4: a limit, no number (the forecaster's own chance of this, stated with the estimate: 15%); middle value at least 3.3-fold (0.52 log units) away from the limit.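

In this assay, the gain seen with compound 2 and compound 3 does not carry over to every hydroxy-bearing chain on this amide-type nitrogen, and compound 4 goes against that pattern. Adding one carbon to the chain of compound 3 reverses the gain, with hydroxymethyl in place of hydroxy giving an at least 3.1-fold higher number from compound 3 to compound 4 (0.49 log units; beyond the scatter), while the comparison with the shorter chain gives an at least 2.5-fold higher number from compound 2 to compound 4 (0.40 log units; beyond the scatter). The step from compound 1 to compound 4 cannot be read, as each compound gives only a limit: the limit of > 50000 nM in this assay, at which 2 of the 4 values shown sit.

On these data alone, how far compound 4 lies past its limit stays open. So does whether an amine or a carboxylic acid in place of the hydroxy on this chain would restore activity.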